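Replacing an iodophenyl with a fluorophenyl on the shared core

A few compounds are considered here, and "the series" means these few. Any claim that something is new, unique, unknown or untested is made for them only; others in the source may bear on it.

Of the compounds shown here, three built on one shared core have been measured in an assay on isolated protein for binding affinity to Equilibrative nucleoside transporter 1 (Homo sapiens); a higher number here means a weaker inhibitor, a lower number a stronger inhibitor. Compound 1, `CCSc1ncnc2c1ncn2[C@@H]1O[C@H](CO)[C@@H](O)[C@H]1O`, carries an ethylsulfanyl group and gives 57500 nM. Compound 2, `OC[C@H]1O[C@@H](n2cnc3c(CSc4ccccc4Cl)ncnc32)[C@H](O)[C@@H]1O`, carries a ((2-chlorophenyl)sulfanyl)methyl group and gives 1780 nM. Compound 3, `OC[C@H]1O[C@@H](n2cnc3c(CSc4cccc(I)c4)ncnc32)[C@H](O)[C@@H]1O`, carries a 3-iodophenyl on the sulfur and gives 245 nM, the lowest number of the three; its nearest neighbour is compound 2, as shown by a 7.3-fold lower number from compound 2 to compound 3 (0.86 log units; beyond the scatter), and the largest gap is a 230-fold lower number from compound 1 to compound 3 (2.37 log units; beyond the scatter).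

Compound 4, `OC[C@H]1O[C@@H](n2cnc3c(CSc4ccc(F)cc4)ncnc32)[C@H](O)[C@@H]1O`, differs from compound 3 in one place: 4-fluorophenyl in place of 3-iodophenyl on a sulfur. Among the compounds with values here, the steps that bear on this are a 32-fold lower number from compound 1 to compound 2 (1.51 log units; beyond the scatter), a 230-fold lower number from compound 1 to compound 3 (2.37 log units; beyond the scatter) and a 7.3-fold lower number from compound 2 to compound 3 (0.86 log units; beyond the scatter): an aryl on the sulfur gives a far lower number than an ethyl, while the choice of halogenated phenyl changed the number modestly. The change to compound 4 keeps an aryl, so the number is expected to stay far below compound 1 but to rise somewhat, an estimated 6.1-fold higher number from compound 3 to compound 4 (0.79 log units; beyond the scatter). Compound 4 is thus expected to give about 1500 nM, within a range from 400 nM to 6000 nM.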

Compound 4, half-maximal inhibitory concentration: 158 nM
Estimate against measurement, compound 4: 9.5-fold (0.98 log units) above, outside the stated range (below it).
By their numbers in this assay, from the lowest: compounds 4 and 3 (each within the scatter of the next); then compound 2; then compound 1.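

In this assay, putting 4-fluorophenyl in place of 3-iodophenyl on the sulfur gives a 1.6-fold lower number from compound 3 to compound 4 (0.19 log units; within the scatter) and so does not separate the two compounds, even though both the halogen and its ring position differ. Compound 2 now stands apart from both, with an 11-fold lower number from compound 2 to compound 4 (1.05 log units; beyond the scatter) showing that among these three halogenated phenyls the 2-chlorophenyl group is the one with the higher number, and a 360-fold lower number from compound 1 to compound 4 (2.56 log units; beyond the scatter) shows that the large gain over ethylsulfanyl also holds with fluorine on the ring. Nothing measured here explains these differences.

A 4-iodophenyl or 3-fluorophenyl group would help separate the effect of the halogen from that of its ring position. As far as these compounds go, it also remains open how a plain phenyl, or a phenyl carrying an amine or a carboxylic acid, would fare on the same sulfur.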